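The source may hold more compounds than are shown below. What is called first, only, known or untested is meant among the compounds shown, and "the series" means these compounds.

Compound 2 `CN1CCN(CCC(=O)NC2CC3(N(C)C)CC(c4ccccc4)C2C(c2ccccc2)C3)CC1` sits second highest of the three numbers in an ADME assay on L6 cells (Rattus norvegicus) for cytotoxicity, read by resazurin assay, with a stated time of 72 h; on this read-out lower numbers stand for stronger inhibition and higher numbers for weaker inhibition. Compound 1 `CN(C)C12CC(N)C(C(c3ccccc3)C1)C(c1ccccc1)C2` gives 40900 nM in this assay, compound 2 gives 95000 nM, and compound 3 `CN1CCN(CC(=O)N2CCC3(N(C)C)CC(c4ccccc4)C2C(c2ccccc2)C3)CC1` gives 195000 nM. Compound 4 `CN1CCN(CC(=O)NC2CC3(N(C)C)CC(c4ccccc4)C2C(c2ccccc2)C3)CC1` differs from compound 2 in one place: 4-methylpiperazin-1-yl in place of (4-methylpiperazin-1-yl)methyl on a saturated chain carbon bound to a carbonyl carbon. Among the compounds with values here, the only measured step with a shared partner is a 2.3-fold higher number from compound 1 to compound 2 (0.37 log units; beyond the scatter), which adds a whole chain rather than shortening one, so it bears only loosely on this change. Shortening the chain by a single carbon is therefore expected to leave the number within the scatter, and a 1.1-fold lower number from compound 2 to compound 4 (0.02 log units; within the scatter) is the expected step. For compound 4, the estimated value is 90000 nM, within a range of 40000 nM to 200000 nM.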

Compound 4, half-maximal inhibitory concentration: 66200 nM
Compound 4: middle estimate off by 1.4-fold (0.13 log units), on the high side; the measured number falls inside the stated range.
By their numbers in this assay, from the lowest: compounds 1, 4 and 2 (each within the scatter of the next, the first and the last beyond it); then compound 3.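

In this assay this chain on the carbonyl gives up one carbon with a 1.4-fold lower number from compound 2 to compound 4 (0.16 log units; within the scatter) so the shortening leaves no readable change in the number. Against the free amine, ((4-methylpiperazin-1-yl)methyl)carbonyl in place of hydrogen on the amine nitrogen gives a 1.6-fold higher number from compound 1 to compound 4 (0.21 log units; within the scatter) and so, unlike the longer chain, cannot be told apart from hydrogen. Nothing measured here explains either step. Still open, on these data alone, is whether a longer chain, or a dimethylamino group in place of 4-methylpiperazin-1-yl, would keep the number in this range.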